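This account rests on a few compounds, and the source may have more. Where it says the series, first, only, none or still open, it means among the compounds named here.

Measured in a functional assay on MDA-MB-231 cells (Homo sapiens) for antiproliferative activity, read by MTT assay, with a stated time of 48 h; a higher number here means a weaker inhibitor, a lower number a stronger inhibitor:
- Compound 1 `Cc1ccc2nc(-c3ccc(Cl)cc3)cc(C(=O)OCc3ccccc3)c2c1`: > 100000 nM, a limit of the assay and not a number.
- Compound 2 `Cc1ccc2nc(-c3ccc(F)cc3)cc(C(=O)OCc3ccccc3)c2c1`: 13200 nM.

Among the compounds with values here, compound 2 gives 13200 nM, which is the only true number so far in this assay, so there is no series to rank it against. The next compound, compound 3 `COc1ccc(-c2cc(C(=O)OCc3ccccc3)c3cc(C)ccc3n2)cc1`, keeps everything else and carries methoxy in place of fluoro on an aromatic carbon, para to a large group: methoxy in place of fluoro on an aromatic carbon.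

Within the data shown here, only one measured step bears on this change, and it involves the same aromatic carbon: an at least 7.5-fold lower number from compound 1 to compound 2 (0.87 log units; beyond the scatter). On these data alone, its true size is unknown, as one end rests on (the limit of > 100000 nM in this assay, at which 1 of the 2 values shown sits). That step is a single pair with a different group, so it is a weak guide. Still, in the one case available, the compound without fluoro at that carbon was the weaker one, so a moderately higher number is expected for methoxy, with a real chance of no change beyond the scatter. The expected step is a 2.3-fold higher number from compound 2 to compound 3 (0.36 log units; beyond the scatter). For compound 3 the estimated value is 30000 nM, with an expected range from 8000 nM to 100000 nM.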

Compound 3, half-maximal inhibitory concentration: 20500 nM
For compound 3 the middle estimate is 1.5-fold (0.17 log units) above the measured one, and the stated range covers the measured number.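

In this assay, the new result shows that fluoro and methoxy on this aromatic carbon cannot be told apart, with a 1.6-fold higher number from compound 2 to compound 3 (0.19 log units; within the scatter), so the swap from 4-fluorophenyl to 4-methoxyphenyl makes no change beyond the scatter. It also shows that the earlier gap was not special to fluoro, since a second group now separates from chloro, with an at least 4.8-fold lower number from compound 1 to compound 3 (0.68 log units; beyond the scatter). The true size of that step stays unknown, as the value for compound 1 is a limit of the assay and not a number: the limit of > 100000 nM in this assay, at which 1 of the 3 values shown sits.

With only three groups shown at this carbon, it remains open whether chloro is an isolated exception among them or whether other groups, such as an amine, a carboxylic acid or a longer chain like butoxy, would behave like fluoro and methoxy. On these data alone, it is also open whether the likeness of compound 2 and compound 3 would hold if the rest of the shared core were changed, as all three compounds keep it the same.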